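Fluorine on the benzyl ring of a pyrrolidine carboxamide

The compounds below may be only part of what the source reports. "The series", "measured", "known", "first", "only" and "open" are said of these compounds alone.

Measured compounds in an assay on HEK293 cells for inhibition of Ataxin-2 (Mus musculus), read by fluorescence and Amplex Red; on this read-out lower numbers stand for stronger inhibition and higher numbers for weaker inhibition:
compound 1 `O=C1CC[C@@H](C(=O)NCc2ccc(OCc3ccc(C(=O)O)cc3)cc2)N1`, > 5000 nM
compound 2 `O=C(O)c1ccc(COc2ccc(CN3C(=O)CC[C@H]3C(=O)NCc3ccccc3)cc2)cc1`, > 5000 nM
compound 3 `O=C(O)c1ccc(COc2ccc(CNC(=O)[C@@H]3CCCN3Cc3ccccc3)cc2)cc1`, > 5000 nM

Compound 1 gives only a limit of the assay, > 5000 nM. Compound 2 likewise gives only a limit, > 5000 nM. Compound 3 also sits at a limit, > 5000 nM, so no number is known for it. All three measured values stand at the same limit, (the limit of > 5000 nM in this assay, at which 3 of the 3 values shown sit), and none of the three can be placed above or below another.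

The next compound, compound 4 `O=C(O)c1ccc(COc2ccc(CNC(=O)[C@@H]3CCCN3Cc3ccc(F)cc3)cc2)cc1`, differs from compound 3 in one place: fluoro in place of hydrogen on an aromatic carbon. The change leaves the carboxylic acid, the ether linkage and the shared core untouched and adds a single fluorine to the benzyl group.

Going by the values given here, no step between measured compounds is available to size the effect of this change. With compound 3 at a limit and the two other measured compounds at the same limit (the limit of > 5000 nM in this assay, at which 3 of the 3 values shown sit), the expectation is that the step from compound 3 to compound 4, a step that the limit leaves unreadable from compound 3 to compound 4, stays within the scatter of this assay. Compound 4 is therefore expected to come out near 10000 nM, within 3000 nM to 40000 nM, and most likely to be reported again as a limit rather than a number.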

Compound 4, half-maximal inhibitory concentration: 800 nM
Compound 4: the middle estimate sits 13-fold (1.10 log units) above what was measured; measured number outside the range, below it.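

In this assay, going by these compounds alone, benzyl to 4-fluorobenzyl gives an at least 6.2-fold lower number from compound 3 to compound 4 (0.79 log units; beyond the scatter), the first step that can be read and one that lies beyond the scatter. It shows that this aromatic carbon, para to a large group, is not a silent position: a single fluorine in place of hydrogen is enough to move the read-out, with the carboxylic acid, the ether linkage and the shared core left as they were, and compound 4 gives a true number, 800 nM. The full size of the step stays unknown, and it can be stated only as a minimum, as compound 3 remains at a limit of the assay, like the two other earlier compounds: the limit of > 5000 nM in this assay, at which 3 of the 4 values shown sit.

The compounds shown leave open whether the gain is particular to fluorine or would also follow from chlorine, a methyl group or a methoxy group on the same carbon. They also leave open how compound 4 would respond if the carboxylic acid gave way to a primary amide or a tetrazole while the 4-fluorobenzyl group stayed in place.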